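The compounds below may be only part of what the source reports. "The series", "measured", "known", "first", "only" and "open" are said of these compounds alone.

Compound 1, with structure `Oc1ccc(-c2cc(-c3ccc(C(F)(F)F)cc3)cc(-c3ccccc3O)n2)cc1`, is tested in a functional assay on HCT-15 cells (Homo sapiens) for inhibition; a higher number here means a weaker inhibitor, a lower number a stronger inhibitor. In this assay compound 1 gives only a limit, > 50000 nM, not a number. Compound 2, with structure `Oc1ccc(-c2cc(-c3ccc(C(F)(F)F)cc3)cc(-c3cccc(O)c3)n2)cc1`, differs from it in one place, (3-hydroxyphenyl in place of 2-hydroxyphenyl on an aromatic carbon), and in this assay compound 2 gives 6440 nM. That change made an at least 7.7-fold lower number from compound 1 to compound 2 (0.89 log units; beyond the scatter); the limit of > 50000 nM in this assay, at which 1 of the 3 values shown sits, means the true size of the step is not pinned down.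

Compound 3, with structure `Oc1cccc(-c2cc(-c3cccc(OC(F)(F)F)c3)cc(-c3ccccc3O)n2)c1`, rests on a different core; how its core differs from that of compound 1 is not broken down here. In this assay compound 3 gives 2740 nM.

Compound 4, with structure `Oc1cccc(-c2cc(-c3cccc(OC(F)(F)F)c3)cc(-c3cccc(O)c3)n2)c1`, has not yet been measured. It differs from compound 3 by 3-hydroxyphenyl in place of 2-hydroxyphenyl on an aromatic carbon. The surroundings of the place differ from the earlier case, being meta to a 3-hydroxyphenyl group and meta to a large group rather than meta to a 4-(trifluoromethyl)phenyl group and a 4-hydroxyphenyl group, so this is the same kind of change, not the same change. From the step seen from compound 1 to compound 2, a step of a 3.9-fold lower number from compound 3 to compound 4 (0.59 log units; beyond the scatter) is expected here, smaller because the earlier step of an at least 7.7-fold lower number from compound 1 to compound 2 (0.89 log units; beyond the scatter) is only a lower bound. Compound 4 is therefore estimated at 700 nM, expected to fall between 250 nM and 2000 nM.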

Compound 4, half-maximal inhibitory concentration: > 50000 nM
Compound 4 ended at the assay's limit; the forecaster's own chance of this, stated with the estimate: 5%; middle value at least 71-fold (1.85 log units) away from the limit.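

Carried to the core of compound 3, the change from 2-hydroxyphenyl to 3-hydroxyphenyl gave an at least 18-fold higher number from compound 3 to compound 4 (1.26 log units; beyond the scatter) in this assay, the opposite direction to the earlier step. The change therefore did not carry from one core to the other, and the two results disagree in direction, not just in size: the same change on two cores in this assay, an at least 7.7-fold lower number (0.89 log units; beyond the scatter) from compound 1 to compound 2 and an at least 18-fold higher number (1.26 log units; beyond the scatter) from compound 3 to compound 4, at least 140-fold (2.15 log units) apart, beyond the scatter of two such steps. Compound 1 and compound 4 each give only a limit, so the true size of neither step is known, and nothing here shows which difference between the two cores reverses the effect: the limit of > 50000 nM in this assay, at which 2 of the 4 values shown sit.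

The compounds shown leave open whether the reversal follows the 4-(trifluoromethyl)phenyl group or the other hydroxyphenyl group, since the two cores differ in more than one place. Also open, going by these compounds, is whether an amine or a methoxy group in place of the hydroxyl on the changed ring would show the same dependence on the core.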